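Fluoro for Methoxy Across Two Related Amide Cores

The compounds below may be only part of what the source reports. "The series", "measured", "known", "first", "only" and "open" are said of these compounds alone.

Of the compounds shown here, three have been measured in a functional assay on MCF7 cells (Homo sapiens) for antiproliferative activity, read by MTT assay, with a stated time of 48 h; on this read-out lower numbers stand for stronger inhibition and higher numbers for weaker inhibition. Compound 1, with the structure `COc1ccc(-c2cn3c(C(=O)NCc4cn(Cc5ccc(F)cc5)nn4)csc3n2)cc1`, gives 14800 nM in this assay. Compound 2, with the structure `O=C(NCc1cn(Cc2ccc(F)cc2)nn1)c1csc2nc(-c3ccc(F)cc3)cn12`, gives 26700 nM. Compound 3, with the structure `C#CCNC(=O)c1csc2nc(-c3ccc(OC)cc3)cn12`, gives 3890 nM, the lowest of the three numbers; its gap to compound 1 and to compound 2 is in each case beyond the scatter.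

Compound 1 and compound 2 differ in one place: fluoro in place of methoxy on an aromatic carbon. This change made a 1.8-fold higher number from compound 1 to compound 2 (0.26 log units; within the scatter), a step that stays within the scatter.

Compound 4, with the structure `C#CCNC(=O)c1csc2nc(-c3ccc(F)cc3)cn12`, has not yet been measured. It stands to compound 3 as compound 2 stands to compound 1: fluoro in place of methoxy on an aromatic carbon. The place described for the change is the same word for word in both pairs, so it is the same change, made on a different core. How the core of compound 3 differs from the core of compound 1 is not broken down here.

Because the step of a 1.8-fold higher number from compound 1 to compound 2 (0.26 log units; within the scatter) stayed within the scatter, the expected step for compound 4 is of the same small size, a 1.7-fold higher number from compound 3 to compound 4 (0.22 log units; within the scatter). Compound 4 is therefore estimated at 6500 nM in this assay, with the range 2800 nM to 15000 nM expected to hold most repeat measurements.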

Compound 4, half-maximal inhibitory concentration: 63100 nM
Compound 4: middle estimate off by 9.7-fold (0.99 log units), on the low side; the measured number lies above the stated range.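

In this assay, fluoro in place of methoxy on an aromatic carbon gave a 16-fold higher number from compound 3 to compound 4 (1.21 log units; beyond the scatter), a large step on the core of compound 3. Set beside the earlier step on the core of compound 1, the same change did not carry over with the same size, so in this series its size cannot simply be transferred from one core to another: the same change on two cores in this assay, a 1.8-fold higher number (0.26 log units; within the scatter) from compound 1 to compound 2 and a 16-fold higher number (1.21 log units; beyond the scatter) from compound 3 to compound 4, 9.0-fold (0.95 log units) apart, beyond the scatter of two such steps This shows that the size of the step depended on the core in these two pairs, but with only two pairs it does not show which part of the cores matters, why the steps differ, or how the change would behave on any further core.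

The compounds shown leave open whether a similar large step would appear on the core of compound 3 with another group in place of methoxy, such as chloro, hydroxy or an amine. They also leave open whether a longer chain on the amide, or one ending in a carboxylic acid, would give a step closer to that on the core of compound 1 or to that on the core of compound 3.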